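Swapping the Ring on the Aromatic Carbon of an Inhibitor

The source may report more compounds than this note shows. Statements on the series, on what has been measured and on what is new or still open speak of the compounds shown alone.

Compound 1 `CC(C)N1CCC(c2ccc3c(c2)oc(=O)n3C(=O)NCCCCc2ccccc2)CC1`: 94 nM
Compound 2 `CC(=O)N1CCC(c2ccc3c(c2)oc(=O)n3C(=O)NCCCCc2ccccc2)CC1`: 64 nM
Compound 3 `CN1CCC(c2ccc3c(c2)oc(=O)n3C(=O)NCCCCc2ccccc2)CC1=O`: 105 nM

All three share one core and differ only in the saturated ring that hangs from the aromatic carbon. In an assay on HEK293 cells for inhibition of acid ceramidase (Homo sapiens), read by fluorescence, with stated times of 10 min and 3 h (a lower number here means a stronger inhibitor, a higher number a weaker inhibitor), their numbers lie close together: a 1.5-fold lower number from compound 1 to compound 2 (0.17 log units; within the scatter), a 1.1-fold higher number from compound 1 to compound 3 (0.05 log units; within the scatter) and a 1.6-fold higher number from compound 2 to compound 3 (0.22 log units; within the scatter), each within the scatter. Compound 3 therefore stands alongside compounds 1 and 2 rather than apart from them.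

Compound 4 `CN1CCN(c2ccc3c(c2)oc(=O)n3C(=O)NCCCCc2ccccc2)C(=O)C1` carries 4-methyl-2-oxopiperazin-1-yl in place of 1-methyl-2-oxopiperidin-4-yl on an aromatic carbon. The ring keeps its size, its carbonyl and its methyl, but a ring nitrogen now joins it to the core. The three measured steps bear on this change and were all small, so no step beyond the scatter is expected for compound 4: a 1.0-fold higher number from compound 3 to compound 4 (0.02 log units; within the scatter). Compound 4 is estimated at 110 nM, within 40 nM to 300 nM.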

Compound 4, half-maximal inhibitory concentration: 52 nM
For compound 4 the middle estimate is 2.1-fold (0.33 log units) above the measured one; the range from low to high includes it.
By their numbers in this assay, from the lowest: compounds 4, 2, 1 and 3 (each within the scatter of the next, the first and the last beyond it).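

Attaching the ring through its nitrogen, as 4-methyl-2-oxopiperazin-1-yl, produced the only step at this position that lies beyond the scatter, namely a 2.0-fold lower number from compound 3 to compound 4 (0.31 log units; beyond the scatter) in this assay, and that step is modest. Against the other two rings the same group shows no clear change, with a 1.2-fold lower number from compound 2 to compound 4 (0.09 log units; within the scatter) and a 1.8-fold lower number from compound 1 to compound 4 (0.26 log units; within the scatter) both staying within the scatter. Nothing available explains the step from the 1-methyl-2-oxopiperidin-4-yl ring.

The compounds shown leave open whether the ring carbonyl of compound 4 is needed, and how a morpholine ring or an open-chain amine on this aromatic carbon would compare.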